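Thiazolidinedione aryl ethers: compound 3 estimate

This account rests on a few compounds, and the source may have more. Where it says the series, first, only, none or still open, it means among the compounds named here.

Measured so far:
compound 1 `O=C1NC(=O)C(Cc2ccc(Oc3ccc(F)cc3)cc2)S1`: 480 nM
compound 2 `Cc1cccc(Oc2ccc(CC3SC(=O)NC3=O)cc2)c1`: 203 nM

Both compounds share the same core and differ only in the aryl group on the ether oxygen. In a functional assay for agonist activity at Free fatty acid receptor 1 (Homo sapiens), read by FLIPR, in the presence of a further agent that is not named here (a higher number here means that more compound is needed for the effect, a lower number that less compound is needed), compound 1 gives 480 nM and compound 2 gives 203 nM; the change is a 2.4-fold lower number from compound 1 to compound 2 (0.37 log units; beyond the scatter). Compound 2 thus stands at the lower of the two numbers recorded so far.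

Compound 3 `O=C1NC(=O)C(Cc2ccc(Oc3ccc(Cl)cc3)cc2)S1` has not yet been measured. Its change from compound 2 is 4-chlorophenyl in place of 3-methylphenyl on an oxygen on an aromatic ring. Within the data shown here, no measured step covers this exact pair. Among the measured compounds shown here, the only related step, a 2.4-fold lower number from compound 1 to compound 2 (0.37 log units; beyond the scatter), shows that a 3-methylphenyl gave a modestly lower number than a 4-fluorophenyl; compound 3 returns to a halogen at the same position, so a modest rise is expected, on the order of a 1.7-fold higher number from compound 2 to compound 3 (0.24 log units; within the scatter). For compound 3 the estimated value in this assay is 350 nM, with a range from 150 nM to 800 nM.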

Compound 3, half-maximal effective concentration: 240 nM
Compound 3: the middle estimate sits 1.5-fold (0.16 log units) above what was measured; low and high end bracket the measured number.
By their numbers in this assay, from the lowest: compounds 2, 3 and 1 (each within the scatter of the next, the first and the last beyond it).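

In this assay, the swap of 3-methylphenyl for 4-chlorophenyl on an oxygen on an aromatic ring gives a 1.2-fold higher number from compound 2 to compound 3 (0.07 log units; within the scatter), so a halogen-bearing ring here can read the same as the 3-methylphenyl ring of compound 2. Chloro in place of fluoro on the same aromatic carbon gives a 2.0-fold lower number from compound 1 to compound 3 (0.30 log units; within the scatter), so compound 3 lies within the scatter of both neighbours, and the earlier gap between compound 1 and compound 2 does not amount to a general separation of halogen from methyl. No measurement bears on why these numbers fall as they do.

Open, going by these compounds, is how this aromatic ring responds to an amine, a carboxylic acid or a methoxy group in place of the chloro. Also open, on these data alone, is whether changes to the shared core would keep the numbers in this range.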